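Swapping Fluoro for Bromo: What to Expect

This account rests on a few compounds, and the source may have more. Where it says the series, first, only, none or still open, it means among the compounds named here.

- compound 1 `COC(=O)C1=C(C)N=C(C)/C(=C(\O)OC)C1c1ccc(F)cc1` gives (129 nM)
- compound 2 `COC(=O)C1=C(C)N=C(C)/C(=C(\O)OC)C1c1ccccc1F` gives (42.7 nM)
- compound 3 `COC(=O)C1=C(C)N=C(C)/C(=C(\O)OC)C1c1ccccc1Br` has not been measured yet

For the measured compounds named here, these values come from a functional assay (muscle tissue) with Cavia porcellus as the target (on this read-out higher numbers stand for an effect only at larger amounts of compound and lower numbers for an effect already at smaller amounts), and, of the two numbers so far, compound 2 has the lowest (42.7 nM). Compound 3 differs from compound 2 in a single place (bromo in place of fluoro on an aromatic carbon), with bromo in place of fluoro on an aromatic carbon, ortho to a large group.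

Going by the values given here, only one measured step offers any guidance (a 3.0-fold lower number from compound 1 to compound 2 (0.48 log units; beyond the scatter)). It is modest and beyond the usual scatter, and it replaces 4-fluorophenyl with 2-fluorophenyl. That step changes where the fluoro sits, while the new change keeps the position and swaps the group. Among the compounds with values here, no measured pair shows such a swap, so the guidance is indirect and the uncertainty is wide. Compound 3 keeps its group at the position of the lower number, so a modest step toward a lower number is expected, though a step within the scatter remains possible.

The expected step is modest (a 2.1-fold lower number from compound 2 to compound 3 (0.33 log units; beyond the scatter)). The estimated value for compound 3 is (20 nM), with an expected range from (6 nM) to (60 nM).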

Compound 3, half-maximal effective concentration: 7.59 nM
The estimate for compound 3 lay 2.6-fold (0.42 log units) above the measured number; the measured number falls inside the stated range.
By their numbers in this assay, from the lowest: compound 3; then compound 2; then compound 1.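

For the compounds shown here, until now, the only measured change moved the fluoro to a different place on the ring, but this change keeps the place, on an aromatic carbon ortho to a large group, and replaces only fluoro with bromo. In this assay that single swap gives a 5.6-fold lower number from compound 2 to compound 3 (0.75 log units; beyond the scatter) and is beyond the usual scatter, so the identity of the group at this place matters, not just where on the ring a group sits. Going by these compounds alone, the change from 4-fluorophenyl to 2-bromophenyl alters both the place and the group, and it gives a 17-fold lower number from compound 1 to compound 3 (1.23 log units; beyond the scatter) as the only large step in this small set, but nothing available here explains why these changes lower the number.

These three compounds leave open whether chloro or iodo at the same place would fit the trend from fluoro to bromo, and whether a group without a halogen, such as methyl or methoxy, would give a similar number. A compound with 4-bromophenyl would show whether bromo also gives a lower number than fluoro at the other place, or whether this gain belongs only to the place ortho to a large group.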